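A few compounds are considered here, and "the series" means these few. Any claim that something is new, unique, unknown or untested is made for them only; others in the source may bear on it.

Of the compounds shown here, two have been tested so far in an assay for binding affinity to adenosine receptor A1 (Bos taurus); on this read-out higher numbers stand for weaker inhibition and lower numbers for stronger inhibition. Compound 1, with the structure `Cc1ccc2c(O)c(C(=O)NCCC(C)C)cnc2n1`, carries an open-chain amide side chain. In this assay compound 1 gives > 10000 nM, which is a limit of the assay and not a number; this is the situation described by the limit of > 10000 nM in this assay, at which 1 of the 2 values shown sits. Compound 2, `Cc1ccc2c(O)c(C(=O)NCc3ccc([N+](=O)[O-])cc3)cnc2n1`, carries instead a benzyl amide bearing a nitro group. In this assay, within the data shown here, compound 2 gives 1630 nM, the only measured number among the values shown, so compound 2 is the sole anchor for what follows.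

Compound 3, `Cc1ccc2c(O)c(C(=O)NCc3ccc(N)cc3)cnc2n1`, is reached from compound 2 by a single change: amino in place of nitro on an aromatic carbon. Among the measured compounds shown here, no measured step between two compounds of this kind exists here, so the size of the effect is open. The expectation is that this assay will show a change from compound 2 to compound 3 of a 1.8-fold higher number from compound 2 to compound 3 (0.26 log units; within the scatter), a step that may well stay within the usual scatter. For compound 3 the estimate is therefore 3000 nM, with a range from 800 nM to 12000 nM.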

Compound 3, inhibition constant: 2860 nM
Compound 3: the middle estimate sits 1.0-fold (0.02 log units) above what was measured; the range from low to high includes it.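

In this assay, the change at this place, para to a large group, gives a 1.8-fold higher number from compound 2 to compound 3 (0.24 log units; within the scatter). Nitro and amino therefore cannot be told apart on this read-out, even though they differ in heavy atoms and hydrogen-bond donors, so this place accepts both groups with no change beyond the scatter. The other step, 4-aminophenyl in place of isobutyl, gives an at least 3.4-fold lower number from compound 1 to compound 3 (0.54 log units; beyond the scatter), which is beyond the scatter and shows that the side chain of the amide matters more here than the swap on the aromatic ring. This step gives only a minimum size, because compound 1 stands at a limit of the assay rather than at a number: the limit of > 10000 nM in this assay, at which 1 of the 3 values shown sits.

Going by these compounds, it remains open whether a different group at the same place, such as chloro or methoxy, would move the value in this assay beyond the scatter. On these data alone, it is also open whether a plain benzyl amide, with only hydrogen at this place, would read like compound 3, and so whether the aromatic ring alone accounts for the step from the isobutyl chain.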